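Replacing 4-nitrophenyl on a sulfur with 2-hydroxyethyl

This account rests on a few compounds, and the source may have more. Where it says the series, first, only, none or still open, it means among the compounds named here.

- Compound 1 `Cc1cn([C@H]2C[C@H](SSc3ccc([N+](=O)[O-])cc3)[C@@H](CO)O2)c(=O)[nH]c1=O` gives 29000 nM in a functional assay on MOLT-4 cells (Homo sapiens) for cytotoxicity; on this read-out higher numbers stand for weaker inhibition and lower numbers for stronger inhibition
- Compound 2 `C=CCSS[C@H]1C[C@H](n2cc(C)c(=O)[nH]c2=O)O[C@@H]1CO` gives 34000 nM in this assay

Compound 1 stands level with compound 2 within the scatter, so neither sets itself apart. Compound 3 `Cc1cn([C@H]2C[C@H](SSCCO)[C@@H](CO)O2)c(=O)[nH]c1=O` has not been measured. The change 2-hydroxyethyl in place of 4-nitrophenyl on a sulfur puts 2-hydroxyethyl in place of 4-nitrophenyl on a sulfur. Among the compounds with values here, the one measured step that bears on it (a 1.2-fold higher number from compound 1 to compound 2 (0.07 log units; within the scatter)) replaces that same 4-nitrophenyl with allyl. Within the data shown here, this is a single step, and no measured compound carries 2-hydroxyethyl. In this assay no shift beyond the scatter is therefore expected, and the estimated step is a 1.1-fold higher number from compound 1 to compound 3 (0.04 log units; within the scatter) with no clear direction. For compound 3 the expected value is 32000 nM with a likely range from 13000 nM to 80000 nM in this estimate.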

Compound 3, half-maximal inhibitory concentration: 128000 nM
Estimate against measurement, compound 3: 4.0-fold (0.60 log units) below; the measured number lies above the stated range.
By their numbers in this assay, from the lowest: compounds 1 and 2 (each within the scatter of the next); then compound 3.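

On the sulfur, the change to 2-hydroxyethyl moved the number beyond the scatter in this assay (a 4.4-fold higher number from compound 1 to compound 3 (0.64 log units; beyond the scatter)), which the change from 4-nitrophenyl to allyl had not done. The step from the allyl compound was of similar modest size, with hydroxymethyl in place of vinyl on the saturated chain carbon bound to a sulfur (a 3.8-fold higher number from compound 2 to compound 3 (0.58 log units; beyond the scatter)). The group on this sulfur therefore does affect the number, but no evidence here explains why.

Going by these compounds, whether the hydroxyl itself accompanies the higher number remains open. A plain ethyl, a 2-methoxyethyl or a 2-aminoethyl group on the same sulfur would help to settle that.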